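The compounds below may be only part of what the source reports. "The series", "measured", "known", "first", "only" and "open" are said of these compounds alone.

In an ADME assay on PBMC cells (Homo sapiens) for cytotoxicity, with a stated time of 5 days (a higher number here means a weaker inhibitor, a lower number a stronger inhibitor), compound 1, `CNc1nc(Cl)nc2c1ncn2[C@H]1C[C@H](N=[N+]=[N-])[C@@H](CO)O1`, gives > 100000 nM, which is a limit of the assay rather than a measured number. Compound 2, `[N-]=[N+]=N[C@H]1C[C@H](n2cnc3c(NCCCCCO)nc(N)nc32)O[C@@H]1CO`, likewise yields in this assay a value of > 100000 nM, again a limit and not a number. Both values sit at the limit of > 100000 nM in this assay, at which 2 of the 2 values shown sit, so compound 1 stands nowhere in particular among the numbers shown: all that is known of it is a limit that the one other measured compound shares. Compound 3, `CN(C)c1nc(Cl)nc2c1ncn2[C@H]1C[C@H](N=[N+]=[N-])[C@@H](CO)O1`, has not yet been tested in this assay. It differs from compound 1 by methyl in place of hydrogen on a nitrogen on an aromatic ring. Among the compounds with values here, no step between two measured compounds is available, so the size of the move from compound 1 to compound 3 in this assay can only be anticipated; the author expects no change beyond the usual scatter, and expects the new value most likely to be reported once more as a limit. The step that this expectation means is a number no higher from compound 1 to compound 3 (the limit leaves the size open). For compound 3 the estimated value in this assay is 100000 nM, with an expected range from 50000 nM to 200000 nM.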

Compound 3, half-maximal inhibitory concentration: > 100000 nM
Compound 3: only a limit was reported (the forecaster's own chance of this, stated with the estimate: 85%); the middle value sits exactly at the limit.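

No step can be read from compound 1 to compound 3 in this assay, since each of them is reported only as a limit: the limit of > 100000 nM in this assay, at which 3 of the 3 values shown sit.

The compounds shown leave open whether methyl in place of hydrogen on a nitrogen on an aromatic ring alters the read-out at all, as none of them gives an actual number in this assay.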